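The source may hold more compounds than are shown below. What is called first, only, known or untested is meant among the compounds shown, and "the series" means these compounds.

Measured so far:
compound 1 `CC[C@H](CCn1cncn1)c1ccccc1`: 97.7 ug/mL
compound 2 `CCC[C@H](CCn1cncn1)c1ccccc1`: 58.4 ug/mL
compound 3 `CCC[C@H](CCn1cncn1)c1ccc(OC)cc1`: 59.6 ug/mL

In an ADME assay on HEp-2 cells (Homo sapiens) for cytotoxicity, read by MTT assay, with a stated time of 3 days (a lower number here means that less compound is tolerated, a higher number that more compound is tolerated), compound 2 holds the smallest of the three numbers shown, but neither neighbour is separated from it beyond the scatter: the step of a 1.0-fold higher number from compound 2 to compound 3 (0.01 log units; within the scatter) is negligible, and the step of a 1.7-fold lower number from compound 1 to compound 2 (0.22 log units; within the scatter) also stays within the scatter. Compound 4 `CCCC[C@H](CCn1cncn1)c1ccccc1` is not yet measured. Its relation to compound 2 is methyl in place of hydrogen on a saturated chain carbon, four bonds along the chain from an aromatic carbon. Among the measured compounds shown here, the one measured step that bears on this change is the chain extension from compound 1 to compound 2, which reads a 1.7-fold lower number from compound 1 to compound 2 (0.22 log units; within the scatter); the methoxy step a 1.0-fold higher number from compound 2 to compound 3 (0.01 log units; within the scatter) concerns the aromatic ring and is uninformative here. For the measured compounds named here, with only one comparable step, and that one inside the scatter, no change beyond the scatter is expected in this assay for compound 4, with at most a mild drift toward a lower number in keeping with the direction from compound 1 to compound 2. The expected step is a 1.3-fold lower number from compound 2 to compound 4 (0.11 log units; within the scatter). Compound 4 is therefore estimated at 45 ug/mL, within a range from 24 ug/mL to 85 ug/mL.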

Compound 4, half-maximal cytotoxic concentration: 50.2 ug/mL
Estimate against measurement, compound 4: 1.1-fold (0.05 log units) below; measured number inside the range.
By their numbers in this assay, from the lowest: compounds 4, 2, 3 and 1 (each within the scatter of the next).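

In this assay, lengthening the chain from propyl to butyl, with methyl in place of hydrogen four bonds along the chain from an aromatic carbon, gives a 1.2-fold lower number from compound 2 to compound 4 (0.07 log units; within the scatter) and so leaves the number within the scatter. The wider change from the chain of compound 1 to that of compound 4 gives a 1.9-fold lower number from compound 1 to compound 4 (0.29 log units; within the scatter) and also stays within the scatter, so ethyl, propyl and butyl are not told apart at this position in this series. No evidence is at hand that accounts for these numbers.

As far as these compounds go, it remains open whether a longer chain such as octyl, or an amine or a carboxylic acid at this place, would move the number beyond the scatter. Also open, from the compounds shown here alone, is whether the methoxy of compound 3 would read the same on the butyl chain.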